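Shifting the hydroxyl on the shared core: compound 2 to compound 4

The source may report more compounds than this note shows. Statements on the series, on what has been measured and on what is new or still open speak of the compounds shown alone.

Compound 1 `Oc1ccc(-c2cc(-c3ccccc3F)cc(-c3ccccc3O)n2)cc1`: in a functional assay on HCT-15 cells (Homo sapiens) for inhibition (on this read-out higher numbers stand for weaker inhibition and lower numbers for stronger inhibition), compound 1 gives only a limit, > 50000 nM.
Compound 2 `Oc1ccc(-c2cc(-c3cccc(F)c3)cc(-c3ccccc3O)n2)cc1`: in this assay compound 2 gives only a limit, > 50000 nM.
Compound 3 `Oc1ccc(-c2cc(-c3ccc(F)cc3)cc(-c3ccccc3O)n2)cc1`: in this assay compound 3 gives only a limit, > 50000 nM.

Compound 2 stands at a limit of this assay and not at a number, and the two other measured values are limits as well (the limit of > 50000 nM in this assay, at which 3 of the 3 values shown sit). The three measured steps, a step that the two limits leave unreadable from compound 1 to compound 2, a step that the two limits leave unreadable from compound 1 to compound 3 and a step that the two limits leave unreadable from compound 2 to compound 3, therefore cannot be read for size or direction; they only show that moving the fluorine around the fluorophenyl group left every compound at the same limit.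

Compound 4 `Oc1ccc(-c2cc(-c3cccc(F)c3)cc(-c3ccc(O)cc3)n2)cc1` differs from compound 2 in one place: 4-hydroxyphenyl in place of 2-hydroxyphenyl on an aromatic carbon. No measured step bears directly on a shift of the hydroxyl on this group, and the steps that exist are all unreadable, so no step beyond the scatter in this assay can be expected in either direction on the evidence shown. The expected outcome is that compound 4 again returns a limit, with an estimated step that the limit leaves unreadable from compound 2 to compound 4.

Compound 4 is thus estimated at 60000 nM in this assay, within a range from 15000 nM to 300000 nM.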

Compound 4, half-maximal inhibitory concentration: > 50000 nM
Compound 4: no number, only a limit (the forecaster's own chance of this, stated with the estimate: 85%); the middle value lies beyond the limit too.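

Compound 4 gives only a limit in this assay, so the shift from 2-hydroxyphenyl to 4-hydroxyphenyl that separates it from compound 2 cannot be read for size or direction: the limit of > 50000 nM in this assay, at which 4 of the 4 values shown sit.

The compounds shown leave open how strongly any of them inhibits in this assay, and whether the place of the hydroxyl or of the fluorine matters there at all.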